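Series notes toward compound 4

This account rests on a few compounds, and the source may have more. Where it says the series, first, only, none or still open, it means among the compounds named here.

Compound 1 `COc1cc(-c2nc(SCc3cn(CC(=O)NC(=O)Nc4ccccn4)nn3)nc(Nc3ccc(C(C)C)cc3)c2C#N)cc(OC)c1OC`, compound 2 `COc1cc(-c2nc(SCc3cn(CC(=O)NC(=O)Nc4ccccn4)nn3)nc(Nc3cccc(C(F)(F)F)c3)c2C#N)cc(OC)c1OC` and compound 3 `N#Cc1c(Nc2cccc(C(F)(F)F)c2)nc(SCc2cn(CC(=O)NC(=O)Nc3ccccn3)nn2)nc1-c1ccc(Br)cc1` share a core. In a functional assay on MCF7 cells (Homo sapiens) for inhibition, read by MTT assay, with a stated time of 72 h (on this read-out lower numbers stand for stronger inhibition and higher numbers for weaker inhibition), compound 1 gives 30900 nM, compound 2 gives 8140 nM and compound 3 gives 3110 nM, the lowest of the three. Compound 4 `CC(C)c1ccc(Nc2nc(SCc3cn(CC(=O)NC(=O)Nc4ccccn4)nn3)nc(-c3ccc(Br)cc3)c2C#N)cc1` has not been measured. The change from compound 2 to compound 1 is 4-isopropylphenyl in place of 3-(trifluoromethyl)phenyl on a nitrogen on an aromatic ring, and in this assay it made a 3.8-fold higher number from compound 2 to compound 1 (0.58 log units; beyond the scatter). The change from compound 3 to compound 4 is 4-isopropylphenyl in place of 3-(trifluoromethyl)phenyl on a nitrogen on an aromatic ring, the same change, its place reading the same word for word. The cores of compound 3 and compound 2 differ by 4-bromophenyl in place of 3,4,5-trimethoxyphenyl on an aromatic carbon, a step of a 2.6-fold lower number from compound 2 to compound 3 (0.42 log units; beyond the scatter) in this assay. The expected step from compound 3 to compound 4 in this assay is a 3.5-fold higher number from compound 3 to compound 4 (0.55 log units; beyond the scatter), beside the earlier one, resting on compound 3 at 3110 nM and on the step of a 3.8-fold higher number from compound 2 to compound 1 (0.58 log units; beyond the scatter). Compound 4 is expected at 11000 nM, between 5000 nM and 25000 nM.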

Compound 4, half-maximal inhibitory concentration: 30600 nM
Beside the measured number, compound 4's estimate is 2.8-fold (0.44 log units) below it; the measured number lies above the stated range.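

In this assay, 4-isopropylphenyl in place of 3-(trifluoromethyl)phenyl on a nitrogen on an aromatic ring gives a 9.8-fold higher number from compound 3 to compound 4 (0.99 log units; beyond the scatter), in the same direction as on the other core, and the two steps do not separate: the same change on two cores in this assay, a 3.8-fold higher number (0.58 log units; beyond the scatter) from compound 2 to compound 1 and a 9.8-fold higher number (0.99 log units; beyond the scatter) from compound 3 to compound 4, 2.6-fold (0.41 log units) apart, within the scatter of two such steps. 4-Bromophenyl in place of 3,4,5-trimethoxyphenyl gives a 1.0-fold lower number from compound 1 to compound 4 (0.00 log units; within the scatter), and this step does not separate from its earlier counterpart either: the same change on two cores in this assay, a 2.6-fold lower number (0.42 log units; beyond the scatter) from compound 2 to compound 3 and a 1.0-fold lower number (0.00 log units; within the scatter) from compound 1 to compound 4, 2.6-fold (0.41 log units) apart, within the scatter of two such steps. Both changes therefore carry across these compounds within the scatter, but one pair per change cannot fix the size of either step or show that it holds on any other core.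

Still open, as far as these compounds go, is whether the first step holds when the phenyl ring on that nitrogen carries a carboxylic acid or an amine. Also open, from the compounds shown here alone, is whether it holds when a longer chain replaces that ring.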